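The source may hold more compounds than are shown below. What is called first, only, known or untested is meant among the compounds shown, and "the series" means these compounds.

Measured compounds in an assay on isolated protein for inhibition of Fatty-acid amide hydrolase 1 (Rattus norvegicus); on this read-out higher numbers stand for weaker inhibition and lower numbers for stronger inhibition:
compound 1 `O=C(CCCCCCc1ccccc1)c1nc(Cl)co1` gives 4 nM
compound 2 `CSc1coc(C(=O)CCCCCCc2ccccc2)n1` gives 29 nM
compound 3 `O=C(CCCCCCc1ccccc1)c1nc(-c2ccccn2)co1` gives 1.9 nM

Compound 3 stands at the lowest number of the three in this assay, with compound 1 nearest (a 2.1-fold lower number from compound 1 to compound 3 (0.32 log units; beyond the scatter)) and compound 2 furthest (a 15-fold lower number from compound 2 to compound 3 (1.18 log units; beyond the scatter)). Compound 4 `O=C(CCCCCCc1ccccc1)c1nc(C(F)(F)F)co1` is not yet measured. It differs from compound 3 in one place: trifluoromethyl in place of pyridin-2-yl on an aromatic carbon. The entering group, like the chloro of compound 1, carries no ring and no hydrogen-bond acceptor, so the step bears most directly on a 2.1-fold lower number from compound 1 to compound 3 (0.32 log units; beyond the scatter), which was modest and ran toward a lower number; the step of a 7.3-fold higher number from compound 1 to compound 2 (0.86 log units; beyond the scatter) marks the other end of what a change at this carbon has done in the series. Replacing the pyridin-2-yl group with a group that has no ring is therefore expected to cost some inhibition: a modest move to a higher number in this assay, about a 3.2-fold higher number from compound 3 to compound 4 (0.50 log units; beyond the scatter), returning compound 4 to the neighbourhood of compound 1. Compound 4 is estimated at 6 nM in this assay, within a range of 2 nM to 20 nM.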

Compound 4, inhibition constant: 3.7 nM
Beside the measured number, compound 4's estimate is 1.6-fold (0.21 log units) above it, within the range that was stated.
By their numbers in this assay, from the lowest: compounds 3, 4 and 1 (each within the scatter of the next, the first and the last beyond it); then compound 2.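

In this assay, trifluoromethyl in place of pyridin-2-yl on this aromatic carbon, next to the ring nitrogen, gives a 1.9-fold higher number from compound 3 to compound 4 (0.29 log units; within the scatter) and so removes both the ring and the hydrogen-bond acceptor of the leaving group without a change beyond the scatter. Trifluoromethyl in place of chloro gives a 1.1-fold lower number from compound 1 to compound 4 (0.03 log units; within the scatter) and does not separate the two groups, whereas trifluoromethyl in place of methylsulfanyl gives a 7.8-fold lower number from compound 2 to compound 4 (0.89 log units; beyond the scatter) and leaves compound 2 apart from the other three compounds. No measurement available here explains why methylsulfanyl stands apart from these groups.

Open, as far as these compounds go, is whether a methoxy group at this carbon would follow methylsulfanyl or stay with chloro and trifluoromethyl. Also open, from the compounds shown here alone, is how an amine or a carboxylic acid at the same carbon would read out in this assay.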